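Working notes: a second methoxy on compound 2

The source may report more compounds than this note shows. Statements on the series, on what has been measured and on what is new or still open speak of the compounds shown alone.

Compound 1 `COc1ccc(C(=O)n2c(-c3cn(C)c4ccccc34)nc3ccccc32)cc1OC` gives 8400 nM
Compound 2 `COc1ccc(C(=O)n2c(-c3cn(C)c4ccc(Br)cc34)nc3ccccc32)cc1` gives 18900 nM

In a functional assay on HepG2 cells (Homo sapiens) for inhibition, read by MTT assay, with a stated time of 24 h (on this read-out lower numbers stand for stronger inhibition of growth and higher numbers for weaker inhibition of growth), compound 2 gives 18900 nM as the higher of the two numbers, beyond the scatter from compound 1. Compound 3 `COc1ccc(C(=O)n2c(-c3cn(C)c4ccc(Br)cc34)nc3ccccc32)cc1OC` differs from compound 2 by methoxy in place of hydrogen on an aromatic carbon as methoxy in place of hydrogen on an aromatic carbon, 4-methoxyphenyl to 3,4-dimethoxyphenyl. Within the data shown here, no measured pair isolates this change. Among the measured compounds shown here, compound 1 also carries 3,4-dimethoxyphenyl, on a different core, and gives 8400 nM as the only guide. The expected 1.7-fold lower number from compound 2 to compound 3 (0.24 log units; within the scatter) is a modest move to a lower number, perhaps not beyond the scatter. Compound 3 is estimated at 11000 nM with an expected range from 4500 nM to 24000 nM in this assay until measured.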

Compound 3, concentration for 50% growth inhibition: 9700 nM
Compound 3: the middle estimate sits 1.1-fold (0.05 log units) above what was measured, within the range that was stated.
By their numbers in this assay, from the lowest: compounds 1, 3 and 2 (each within the scatter of the next, the first and the last beyond it).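

In this assay, methoxy in place of hydrogen at this position, ortho to a methoxy group, gives a 1.9-fold lower number from compound 2 to compound 3 (0.29 log units; within the scatter), so 4-methoxyphenyl and 3,4-dimethoxyphenyl are not told apart here. With 3,4-dimethoxyphenyl kept, bromo in place of hydrogen on an aromatic carbon gives a 1.2-fold higher number from compound 1 to compound 3 (0.06 log units; within the scatter), so that change is not resolved either. No supporting data bear on these steps.

On these data alone, whether an amine or a carboxylic acid at this position, or a longer chain in place of the methoxy, would move the number beyond the scatter stays open.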